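Adding a 4-Methoxyphenyl Group to a Second Core

The source may report more compounds than this note shows. Statements on the series, on what has been measured and on what is new or still open speak of the compounds shown alone.

Compound 1 `Cn1nc(-c2ccccc2)c2cc(C(=N)Nc3ccccc3)ncc21` carries a methyl group on a ring nitrogen and, in a functional assay on MDA-MB-231 cells (Homo sapiens) for cytotoxicity, read by MTT assay, with a stated time of 72 h (on this read-out higher numbers stand for weaker inhibition and lower numbers for stronger inhibition), compound 1 gives 11100 nM. Compound 3 `COc1ccc(Cn2nc(-c3ccccc3)c3cc(C(=N)Nc4ccccc4)ncc32)cc1` keeps the same core but bears a 4-methoxyphenyl group where compound 1 has only a hydrogen; in this assay compound 3 gives 5400 nM. The change between them is 4-methoxyphenyl in place of hydrogen on a saturated chain carbon bound to an aromatic nitrogen, and it produced a 2.1-fold lower number from compound 1 to compound 3 (0.31 log units; beyond the scatter), so the larger group went with a somewhat stronger effect on the cells.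

Compound 2 `CN1CCN(c2ccc(NC(=N)c3cc4cnn(C)c4cn3)cc2)CC1` belongs to a different core, and the difference between the two cores is not broken down here. In this assay compound 2 gives 30200 nM, the highest of the three numbers, above compound 1 and further still above compound 3.

Compound 4 `COc1ccc(Cn2ncc3cc(C(=N)Nc4ccc(N5CCN(C)CC5)cc4)ncc32)cc1` has not yet been measured. Among the measured compounds shown here, it differs from compound 2 by 4-methoxyphenyl in place of hydrogen on a saturated chain carbon bound to an aromatic nitrogen, at the same place as before, so it is the same change as the one from compound 1 to compound 3. Compound 4 is expected to show a step of a 2.2-fold lower number from compound 2 to compound 4 (0.33 log units; beyond the scatter), matching in direction and roughly in size the earlier step because the same change gave a 2.1-fold lower number from compound 1 to compound 3 (0.31 log units; beyond the scatter). Compound 4 is therefore estimated at 14000 nM, with a likely range from 6000 nM to 32000 nM, resting on a single prior example and a core whose own behaviour is known only from compound 2.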

Compound 4, half-maximal inhibitory concentration: 5700 nM
Estimate against measurement, compound 4: 2.5-fold (0.39 log units) above; the measured number lies below the stated range.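

In this assay, the same exchange on the core of compound 2 gave a 5.3-fold lower number from compound 2 to compound 4 (0.72 log units; beyond the scatter), so the number fell on this core as it did on the core of compound 1. The change therefore carried over in direction, and although the new step looks larger, the two steps cannot be told apart in size: the same change on two cores in this assay, a 2.1-fold lower number (0.31 log units; beyond the scatter) from compound 1 to compound 3 and a 5.3-fold lower number (0.72 log units; beyond the scatter) from compound 2 to compound 4, 2.6-fold (0.41 log units) apart, within the scatter of two such steps. Among the compounds shown here, this rests on only two matched pairs, so it does not show that the change would act the same way on any further core, and it gives no reason why the numbers fall.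

At this place the compounds shown carry only methyl and 4-methoxybenzyl, so it remains open whether the methoxy group matters or whether a plain benzyl group, or a longer chain such as propyl, would lower the number as well. All these readings also come from a single cancer cell line, which leaves open whether the same step would appear in other cells, including healthy ones.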